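Adding a 2-methoxyethyl to compound 3

This account rests on a few compounds, and the source may have more. Where it says the series, first, only, none or still open, it means among the compounds named here.

In a functional assay on NCI-H460 cells (Homo sapiens) for antiproliferative activity, read by MTT assay, with a stated time of 72 h (a higher number here means a weaker inhibitor, a lower number a stronger inhibitor), compound 3 `O=c1c(-c2ccc(F)cc2)c[nH]c2ccnc(Nc3ccc(Oc4ccnc5cc(O)ccc45)c(F)c3)c12` gives 43000 nM, the highest of the three numbers and beyond the scatter from the other two. Compound 1 `COc1cc2c(Oc3ccc(Nc4nccc5[nH]cc(-c6ccc(F)cc6)c(=O)c45)cc3F)ccnc2cc1OCCO` gives 2000 nM, and compound 2 `COCCOc1cc2nccc(Oc3ccc(Nc4nccc5[nH]cc(-c6ccc(F)cc6)c(=O)c45)cc3F)c2cc1OC` gives 3000 nM.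

Compound 4 `COCCOc1ccc2c(Oc3ccc(Nc4nccc5[nH]cc(-c6ccc(F)cc6)c(=O)c45)cc3F)ccnc2c1` differs from compound 3 in one place: 2-methoxyethyl in place of hydrogen on an oxygen on an aromatic ring. Put simply, hydroxy becomes 2-methoxyethoxy. Among the compounds with values here, the only measured step that bears on this is a 1.5-fold higher number from compound 1 to compound 2 (0.18 log units; within the scatter), with methyl in place of hydrogen on an oxygen on a saturated carbon. That step stays within the scatter, so the two chains look alike here. Compound 4 carries the same 2-methoxyethoxy as compound 2, which gives 3000 nM. However, compound 1 and compound 2 also hold a further group that compound 3 and compound 4 lack, and no measurement separates its share. Most of the gap should still close, though perhaps not all of it. An estimated 8.6-fold lower number from compound 3 to compound 4 (0.93 log units; beyond the scatter) is therefore expected in this assay. Compound 4 is expected at 5000 nM, within an estimated range of 1500 nM to 20000 nM.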

Compound 4, half-maximal inhibitory concentration: 4300 nM
For compound 4 the middle estimate is 1.2-fold (0.07 log units) above the measured one; low and high end bracket the measured number.
By their numbers in this assay, from the lowest: compounds 1, 2 and 4 (each within the scatter of the next, the first and the last beyond it); then compound 3.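

In this assay, the first direct test at this position gives a 10-fold lower number from compound 3 to compound 4 (1.00 log units; beyond the scatter), so replacing hydroxy with 2-methoxyethoxy on the aromatic ring changes the result by more than the usual scatter. The second step, with hydrogen in place of methoxy on an aromatic carbon, gives a 1.4-fold higher number from compound 2 to compound 4 (0.16 log units; within the scatter), so the extra methoxy makes no clear difference once the 2-methoxyethoxy is present and cannot account for the large gap to compound 3. No supporting measurement is available to explain why the 2-methoxyethyl has this effect.

On these data alone, it remains open whether the whole chain is needed or whether a simple methyl on the same oxygen would serve as well. A longer chain ending in an amine, such as a morpholine, is another open case.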